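Amide nitrogen substituent and cytotoxicity in this series

The source may report more compounds than this note shows. Statements on the series, on what has been measured and on what is new or still open speak of the compounds shown alone.

Compound 1 `Cc1cc(C)cc(S(=O)(=O)c2c(C(=O)NCc3cccc(F)c3F)[nH]c3ccc(Cl)cc23)c1` reaches only the limit of an ADME assay on MT4 cells (Homo sapiens) for cytotoxicity, read by MTT assay (on this read-out higher numbers stand for lower toxicity in this test and lower numbers for higher toxicity in this test), at > 51100 nM. Among the compounds with values here, compound 2 `Cc1cc(C)cc(S(=O)(=O)c2c(C(=O)Nc3ccnc(C#N)c3)[nH]c3ccc(Cl)cc23)c1` gives 6840 nM in this assay, the only measured number in the set. The other value shown is a limit. Within the data shown here, the single measured step is an at least 7.4-fold lower number from compound 1 to compound 2 (0.87 log units; beyond the scatter), its size bounded by the limit of > 51100 nM in this assay, at which 1 of the 2 values shown sits. Compound 3 `Cc1cc(C)cc(S(=O)(=O)c2c(C(=O)NC(C)C(=O)NCc3ccco3)[nH]c3ccc(Cl)cc23)c1` differs from compound 2 by 1-(((furan-2-yl)methyl)carbamoyl)ethyl in place of 2-cyanopyridin-4-yl on an amide-type nitrogen. Since an at least 7.4-fold lower number from compound 1 to compound 2 (0.87 log units; beyond the scatter) accompanied 2-cyanopyridin-4-yl replacing 2,3-difluorobenzyl, and compound 3 removes the 2-cyanopyridin-4-yl again, a rise in this assay is expected, a 4.4-fold higher number from compound 2 to compound 3 (0.64 log units; beyond the scatter). Compound 3 is estimated at 30000 nM, between 8000 nM and 60000 nM, possibly again only a limit.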

Compound 3, half-maximal cytotoxic concentration: 24200 nM
The estimate for compound 3 lay 1.2-fold (0.09 log units) above the measured number, within the range that was stated.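

At this amide-type nitrogen, the low number of compound 2 does not carry over to every other substituent: in this assay, 1-(((furan-2-yl)methyl)carbamoyl)ethyl in place of 2-cyanopyridin-4-yl gives a 3.5-fold higher number from compound 2 to compound 3 (0.55 log units; beyond the scatter). The rise does not fully return the series to the level of compound 1, as the same change from 2,3-difluorobenzyl gives an at least 2.1-fold lower number from compound 1 to compound 3 (0.32 log units; beyond the scatter). The size of that second step is open at one end: the limit of > 51100 nM in this assay, at which 1 of the 3 values shown sits.

Still open, as far as these compounds go, is whether the rise follows the loss of the nitrile, the loss of the pyridine ring or the gain of the furan-bearing chain. A plain pyridin-4-yl or phenyl on this nitrogen would help separate these.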